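A few compounds are considered here, and "the series" means these few. Any claim that something is new, unique, unknown or untested is made for them only; others in the source may bear on it.

Of the compounds shown here, two built on a shared core have been tested in a functional assay on CHO cells for agonist activity at Melanocortin receptor 4 (Homo sapiens), read by cAMP accumulation; on this read-out lower numbers stand for an effect already at smaller amounts and higher numbers for an effect only at larger amounts of compound. Compound 1 `CC(C)[C@H](NC(=O)CCN(C)C)c1cccc(F)c1N1CCN(C(=O)[C@@H]2CN(C(C)C)C[C@H]2c2ccc(Cl)cc2)CC1` gives 20 nM. Compound 2 `CNCC(=O)N[C@H](c1cc(C)ccc1N1CCN(C(=O)[C@@H]2CN(C3CCOCC3)C[C@H]2c2ccc(Cl)cc2)CC1)C(C)C` gives 19 nM in this assay, the smallest number shown, with compound 1 sitting within the usual scatter of it. Compound 3 `Cc1ccc(N2CCN(C(=O)[C@@H]3CN(C4CCOCC4)C[C@H]3c3ccc(Cl)cc3)CC2)c([C@@H](NC(=O)CCN)C(C)C)c1` keeps the same atoms as compound 2 but joins them differently in one place: aminomethyl in place of methylamino on a saturated chain carbon bound to a carbonyl carbon. Among the compounds with values here, no measured pair shows this change, so the expected step of no change at the digits printed from compound 2 to compound 3 (within the scatter) is none beyond the scatter. For compound 3 the estimate in this assay is 19 nM, with a range from 8 nM to 45 nM.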

Compound 3, half-maximal effective concentration: 6 nM
Estimate against measurement, compound 3: 3.2-fold (0.50 log units) above; measured number below the stated range.
By their numbers in this assay, from the lowest: compound 3; then compounds 2 and 1 (each within the scatter of the next).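

In this assay, rejoining the same atoms gives a 3.2-fold lower number from compound 2 to compound 3 (0.50 log units; beyond the scatter) and so shows that aminomethyl in place of methylamino on a saturated chain carbon bound to a carbonyl carbon is not a silent swap. The hydrogen-bond donor and acceptor counts of the two groups match, so those counts alone do not predict the outcome at this position. Nothing available here accounts for the step. Still open, going by these compounds, is how a 3-aminopropyl group would compare at this place, and whether a hydroxyl in place of the terminal amine would keep the lower number.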